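A few compounds are considered here, and "the series" means these few. Any claim that something is new, unique, unknown or untested is made for them only; others in the source may bear on it.

Working notes on the urea series, read in an ADME assay on HepG2 cells (Homo sapiens) for cytotoxicity, with a stated time of 72 h; on this read-out lower numbers stand for an effect already at smaller amounts and higher numbers for an effect only at larger amounts of compound. Compound 1 `CCc1ccc(NC(=O)Nc2cc(C)nc3ccccc23)cc1` gives 17000 nM. Compound 2 `Cc1cc(NC(=O)Nc2ccc(F)cc2)c2ccccc2n1` reports only > 25000 nM, which is a limit of the assay rather than a number; this is the limit of > 25000 nM in this assay, at which 1 of the 2 values shown sits. Among the measured compounds shown here, the one measured step, an at least 1.4-fold higher number from compound 1 to compound 2 (0.16 log units; that floor lies within the scatter), is therefore itself only a floor and lies within the scatter. Compound 3 `Cc1cc(NC(=O)Nc2ccccc2F)c2ccccc2n1` is the next member: 2-fluorophenyl in place of 4-fluorophenyl on an amide-type nitrogen. For the measured compounds named here, no measured pair in the set exchanges one fluorophenyl for another, so the sole step between compound 1 and compound 2 gives no direct reading on this change; it shows only that compound 2 sits at the edge of the window of this assay. The expectation for compound 3 is a step of a number no higher from compound 2 to compound 3 (the limit leaves the size open), nothing beyond the scatter, with a good chance that this assay again reports only a limit. Compound 3 is therefore estimated at 25000 nM, within 12000 nM to 60000 nM.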

Compound 3, half-maximal effective concentration: > 25000 nM
Compound 3: a limit, no number; the forecaster's own chance of this, stated with the estimate: 60%; the middle value sits exactly at the limit.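

No step can be read between compound 2 and compound 3, as both end at limits. Compound 3 gives > 25000 nM, a limit and not a number: the limit of > 25000 nM in this assay, at which 2 of the 3 values shown sit. Still open, going by these compounds, is whether 2-fluorophenyl and 4-fluorophenyl differ at all in this assay.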